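The source may report more compounds than this note shows. Statements on the series, on what has been measured and on what is new or still open speak of the compounds shown alone.

Measured so far in a functional assay on MCF7 cells (Homo sapiens) for antiproliferative activity, read by MTT assay, with a stated time of 24 h, tested at 12.5 uM; a higher number here means a weaker effect of the compound at the concentration tested, a lower number a stronger effect:
compound 1, `C[C@@H](O)CCn1nc2c(Br)c(Br)c(Br)c(Br)c2n1` — 109%
compound 2, `C[C@H](O)CCn1nc2c(Br)c(Br)c(Br)c(Br)c2n1` — 112%
compound 3, `CC(O)CCn1nc2c(Br)c(Br)c(Br)c(Br)c2n1` — 99%

Compound 3 gives the lowest of the three numbers. The step of a number 10 percentage points lower from compound 1 to compound 3 (within the scatter) stays within the scatter, whereas the step of a number 13 percentage points lower from compound 2 to compound 3 (beyond the scatter) lies just beyond it; the step of a number 3 percentage points higher from compound 1 to compound 2 (within the scatter) is within the scatter.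

Compound 4, `OCC(O)Cn1nc2c(Br)c(Br)c(Br)c(Br)c2n1`, is the next compound and differs from compound 3 by 1,2-dihydroxyethyl in place of 2-hydroxypropyl on a saturated chain carbon bound to an aromatic nitrogen. All three measured steps concern configuration alone, as shown by the fact that compounds 1 and 2 differ only in the configuration as drawn, the fact that one of compounds 1 and 3 is drawn with a defined configuration and the other without, at the place where they differ and (the fact that one of compounds 2 and 3 is drawn with a defined configuration and the other without, at the place where they differ); none alters the side chain, so none bears on this change. Among the measured compounds shown here, with no comparable measured step, no movement beyond the scatter is expected in this assay. Compound 4 is therefore estimated at 100%, between 82% and 118%. That estimate means a step of a number 1 percentage points higher from compound 3 to compound 4 (within the scatter), expected to remain within the scatter.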

Compound 4, a percentage reported as activity, at one concentration (the size of the read-out at that concentration, not a potency): 145%
Estimate against measurement, compound 4: 45 percentage points below; measured number above the stated range.
By their numbers in this assay, from the lowest: compounds 3, 1 and 2 (each within the scatter of the next, the first and the last beyond it); then compound 4.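

In this assay, the side chain at this place proves able to move the read-out towards a weaker effect: 1,2-dihydroxyethyl in place of 2-hydroxypropyl gives a number 46 percentage points higher from compound 3 to compound 4 (beyond the scatter) and likewise a number 33 percentage points higher from compound 2 to compound 4 (beyond the scatter) and a number 36 percentage points higher from compound 1 to compound 4 (beyond the scatter) in the same direction. Each of these steps exceeds any step seen among compounds differing only in configuration. The evidence available concerns configuration alone and gives no cause for this change.

From the compounds shown here alone, it remains open how an amine, a carboxylic acid or a longer chain at this place would read in this assay. Going by these compounds, whether the configuration of the 1,2-dihydroxyethyl group matters also remains open.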